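The compounds below may be only part of what the source reports. "The series", "measured", "known", "first", "only" and "open" are said of these compounds alone.

Measured so far:
compound 1, `C=CC(=O)NCCCCc1ccc2ncn(-c3ccnc(N)n3)c2c1`, 501000 nM in an assay on Sf9 cells for inhibition of mitogen-activated protein kinase kinase kinase 14 variant S549D (Homo sapiens), with a stated time of 30 min, in the presence of a further agent that is not named here; on this read-out higher numbers stand for weaker inhibition and lower numbers for stronger inhibition
compound 2, `C=Cc1cc(C#Cc2ccc3ncn(-c4ccnc(N)n4)c3c2)ccn1`, 20000 nM in this assay

Of these two numbers, compound 2 has the lower one, so it is the stronger inhibitor of the pair; compound 1 has the higher one, and the gap between them is beyond the usual scatter. For the measured compounds named here, no single-change step between measured compounds is available, so there is no measured guide to the change considered next.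

Compound 3, `C#Cc1cncc(C#Cc2ccc3ncn(-c4ccnc(N)n4)c3c2)n1`, is not yet measured. Compared with compound 2 it differs as follows: a group of 8 heavy atoms (6 carbon, 2 nitrogen; one six-membered aromatic ring with 2 hetero atoms) in place of a group of 8 heavy atoms (7 carbon, 1 nitrogen; one six-membered aromatic ring with 1 hetero atom), on a triple-bonded carbon. Going by the values given here, with no measured step of this kind to rest on, the expected change is small, and the step from compound 2 to compound 3 is estimated as a 1.5-fold higher number from compound 2 to compound 3 (0.18 log units; within the scatter), a slight weakening that may well fall within the scatter. Compound 3 is accordingly expected to give about 30000 nM, with a likely range of 8000 nM to 110000 nM.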

Compound 3, half-maximal inhibitory concentration: 6310 nM
Compound 3: the middle estimate sits 4.8-fold (0.68 log units) above what was measured; the measured number lies below the stated range.
By their numbers in this assay, from the lowest: compound 3; then compound 2; then compound 1.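

For the compounds shown here, at this position, on a triple-bonded carbon, the exchange of the 2-vinylpyridin-4-yl group for a ring with 2 hetero atoms and a triple bond outside the ring brings a 3.2-fold lower number from compound 2 to compound 3 (0.50 log units; beyond the scatter) in this assay and gives the first comparison of compounds that differ in one place. Both groups hold 8 heavy atoms, so the step shows that the number can move even when the size of the group, counted in heavy atoms, stays the same. Nothing measured on these compounds explains the step.

Going by these compounds, the second ring nitrogen and the triple bond in place of the double bond arrive together, so the share of each in the step stays open. On these data alone, how an amine or a nitrile in place of that triple bond would read is also open.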